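This account rests on a few compounds, and the source may have more. Where it says the series, first, only, none or still open, it means among the compounds named here.

Working notes on the amide series. Three compounds have been run in an assay for inhibition of serine/threonine-protein kinase Sgk1 (Homo sapiens), with stated times of 30 min and 60 min, in the presence of a further agent that is not named here; on this read-out lower numbers stand for stronger inhibition and higher numbers for weaker inhibition. Compound 1 `O=C(N[C@@H]1CCNC1)c1cc(-c2ccc(NS(=O)(=O)c3cccc(Cl)c3Cl)cc2)nc2[nH]ncc12` reaches only a limit of the read-out, < 1 nM, which is the limit of < 1 nM in this assay, at which 1 of the 3 values shown sits. Compound 2 `CN1CCC(NC(=O)c2cc(-c3ccc(NS(=O)(=O)c4cccc(Cl)c4Cl)cc3)nc3[nH]ncc23)C1` gives 21 nM. Compound 3 `O=C(NC1CCN(CC2CC2)C1)c1cc(-c2ccc(NS(=O)(=O)c3cccc(Cl)c3Cl)cc2)nc2[nH]ncc12` gives 35 nM; this is the higher of the two numbers shown, with compound 2 as its nearest neighbour, and the step of a 1.7-fold higher number from compound 2 to compound 3 (0.22 log units; within the scatter) lies within the scatter. The two steps out of compound 1 are both large: an at least 21-fold higher number from compound 1 to compound 2 (1.32 log units; beyond the scatter) and an at least 35-fold higher number from compound 1 to compound 3 (1.54 log units; beyond the scatter), so any substituent on the ring nitrogen carries a clear cost, whereas the size of that substituent, as in a 1.7-fold higher number from compound 2 to compound 3 (0.22 log units; within the scatter), does not.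

Compound 4 `CNC(=O)c1cc(-c2ccc(NS(=O)(=O)c3cccc(Cl)c3Cl)cc2)nc2[nH]ncc12` takes this one step further: methyl in place of 1-(cyclopropylmethyl)pyrrolidin-3-yl on an amide-type nitrogen. Within the data shown here, no measured step covers removal of the whole ring; the measured steps only compare substituents on it. The expected change a 2.3-fold higher number from compound 3 to compound 4 (0.36 log units; beyond the scatter) is therefore taken as moderate and towards a higher number, since the numbers rise once the ring nitrogen is no longer free, as in an at least 35-fold higher number from compound 1 to compound 3 (1.54 log units; beyond the scatter), and the smallest group in the series sits on the opposite end of that trend. For compound 4 the estimate in this assay is 80 nM, with a range from 15 nM to 500 nM.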

Compound 4, half-maximal inhibitory concentration: 929 nM
The estimate for compound 4 lay 12-fold (1.06 log units) below the measured number; measured number outside the range, above it.
By their numbers in this assay, from the lowest: compounds 2 and 3 (each within the scatter of the next); then compound 4. At a limit, below all of these: compound 1.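

Methyl on the amide-type nitrogen costs far more than any change made on the pyrrolidine ring nitrogen among the ring-bearing compounds, as this assay shows for the loss of the whole ring (a 27-fold higher number from compound 3 to compound 4 (1.42 log units; beyond the scatter)) and again from the smaller ring substituent (a 44-fold higher number from compound 2 to compound 4 (1.65 log units; beyond the scatter)). Both steps are large, so the earlier picture, in which only a free ring nitrogen mattered and the size of its substituent did not, is incomplete: even with a substituted ring nitrogen, the 1-methylpyrrolidin-3-yl and 1-(cyclopropylmethyl)pyrrolidin-3-yl groups keep much of what methyl loses. Compound 1 stands at a limit of the read-out, so its step to methyl (an at least 920-fold higher number from compound 1 to compound 4 (2.96 log units; beyond the scatter)) gives only a bound on the full span at this position: the limit of < 1 nM in this assay, at which 1 of the 4 values shown sits.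

The compounds shown leave open whether the ring nitrogen is needed at all once the ring is present, which a cyclopentyl group on the amide-type nitrogen would separate. They also leave open whether the ring itself is needed, which an open 2-aminoethyl chain carrying a free amine in the same place would test.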